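Acylation of the amine in a melanocortin 4 series

This account rests on a few compounds, and the source may have more. Where it says the series, first, only, none or still open, it means among the compounds named here.

Measured compounds:
compound 1 `CC(C)C[C@H](N)c1cc(C(F)(F)F)ccc1N1CCN(C(=O)[C@H]2CS(=O)(=O)C[C@@H]2c2ccc(Cl)cc2)CC1` — 38 nM
compound 2 `CC(C)C[C@H](N)c1cc(C(F)(F)F)ccc1N1CCN(C(=O)C2COCC2c2ccc(Cl)cc2)CC1` — 280 nM
compound 3 `CNCCC(=O)N[C@@H](CC(C)C)c1cc(C(F)(F)F)ccc1N1CCN(C(=O)[C@H]2CSC[C@@H]2c2ccc(Cl)cc2)CC1` — 170 nM

In an assay on HEK293 cells for displacement of a labelled ligand from Melanocortin receptor 4 (Homo sapiens) (a lower number here means a stronger inhibitor, a higher number a weaker inhibitor), compound 1 gives 38 nM, the lowest of the three numbers. Compound 3 stands nearest with 170 nM, a gap beyond the scatter, and compound 2 is furthest with 280 nM, also beyond the scatter.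

Compound 4 `CNCCC(=O)N[C@@H](CC(C)C)c1cc(C(F)(F)F)ccc1N1CCN(C(=O)[C@H]2CS(=O)(=O)C[C@@H]2c2ccc(Cl)cc2)CC1` has not been measured. It differs from compound 1 by (2-(methylamino)ethyl)carbonyl in place of hydrogen on an amine nitrogen. Among the measured compounds shown here, no direct step of this kind between two measured compounds is available. Compound 3 carries the same (2-(methylamino)ethyl)carbonyl group on its amine nitrogen and differs from compound 4 only elsewhere in the core. Compound 3 gives 170 nM, whereas compound 1 gives 38 nM, and this is all that the measured compounds show. On that basis compound 4 is expected to give a higher number than compound 1, a step of a 3.4-fold higher number from compound 1 to compound 4 (0.53 log units; beyond the scatter) that should lie beyond the scatter. The estimate for compound 4 in this assay is 130 nM, with a range from 40 nM to 400 nM.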

Compound 4, inhibition constant: 190 nM
Estimate against measurement, compound 4: 1.5-fold (0.16 log units) below, within the range that was stated.
By their numbers in this assay, from the lowest: compound 1; then compounds 3, 4 and 2 (each within the scatter of the next).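

In this assay, the effect of acylating this amine nitrogen can now be read directly: (2-(methylamino)ethyl)carbonyl in place of hydrogen gives a 5.0-fold higher number from compound 1 to compound 4 (0.70 log units; beyond the scatter) and is a modest step. The amine nitrogen therefore tolerates this acylation with some loss, and compound 1, with its free amine, keeps the lowest number of the four. Compound 3 and compound 4 carry the same acyl group, differ only elsewhere in the core and stand within the scatter of each other, so the two acylated compounds do not separate in this assay. No measurement at hand explains the step.

The compounds shown leave open whether the step comes from the carbonyl on the amine nitrogen or from the methylamino end of the chain, and a plain acetyl group on the same nitrogen would separate the two. They also leave open how the length of the chain and the substitution at its end matter, as would be tested by a longer chain ending in a dimethylamino group or a chain ending in a carboxylic acid.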